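The source may hold more compounds than are shown below. What is called first, only, known or untested is meant among the compounds shown, and "the series" means these compounds.

Three compounds share one core: a ring holding an amide-type nitrogen, from which a saturated chain runs out to an amine. Compound 1 `CN(CCCN1C(=O)CSC1c1cc(C(C)(C)C)c(O)c(C(C)(C)C)c1)CC1CC1` ends that chain in a (cyclopropylmethyl)(methyl)amino group, and in a functional assay on aorta for inhibition of Voltage-dependent L-type calcium channel subunit alpha-1C (Rattus norvegicus) (on this read-out lower numbers stand for stronger inhibition and higher numbers for weaker inhibition), compound 1 gives 1200 nM. Compound 2 `CC(C)(C)c1cc(C2SCC(=O)N2CCCN)cc(C(C)(C)C)c1O` carries a plain amino group there and gives 4400 nM, while compound 3 `CN(C)CCN(C)CCCN1C(=O)CSC1c1cc(C(C)(C)C)c(O)c(C(C)(C)C)c1` carries a (2-(dimethylamino)ethyl)(methyl)amino group and gives 1700 nM. Compound 3 thus stands second highest of the three numbers: its nearest neighbour is compound 1, with a 1.4-fold higher number from compound 1 to compound 3 (0.15 log units; within the scatter), and its furthest is compound 2, with a 2.6-fold lower number from compound 2 to compound 3 (0.41 log units; beyond the scatter). Compound 4 `CN(CCCN1C(=O)CSC1c1cc(C(C)(C)C)c(O)c(C(C)(C)C)c1)Cc1ccccc1` differs from compound 3 by phenyl in place of (dimethylamino)methyl on a saturated chain carbon bound to an amine nitrogen. The step that bears most on this change is the one that also swapped a group on that same chain carbon, a 1.4-fold higher number from compound 1 to compound 3 (0.15 log units; within the scatter); the larger steps of a 3.7-fold higher number from compound 1 to compound 2 (0.56 log units; beyond the scatter) and a 2.6-fold lower number from compound 2 to compound 3 (0.41 log units; beyond the scatter) came from stripping or rebuilding the whole substituted amine, which compound 4 keeps. A step of a 1.3-fold lower number from compound 3 to compound 4 (0.12 log units; within the scatter) is therefore expected, within the scatter. Compound 4 is estimated at 1300 nM, with a range from 500 nM to 3500 nM.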

Compound 4, half-maximal inhibitory concentration: 600 nM
Beside the measured number, compound 4's estimate is 2.2-fold (0.34 log units) above it, within the range that was stated.
By their numbers in this assay, from the lowest: compounds 4, 1 and 3 (each within the scatter of the next, the first and the last beyond it); then compound 2.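

In this assay, the group on a saturated chain carbon bound to an amine nitrogen can shift the number beyond the scatter: (dimethylamino)methyl in place of cyclopropyl gave a 1.4-fold higher number from compound 1 to compound 3 (0.15 log units; within the scatter), but phenyl in place of (dimethylamino)methyl gives a 2.8-fold lower number from compound 3 to compound 4 (0.45 log units; beyond the scatter). Phenyl in place of cyclopropyl gives a 2.0-fold lower number from compound 1 to compound 4 (0.30 log units; within the scatter), so these two groups cannot be told apart at this place. Benzyl(methyl)amino in place of the plain amino group gives a 7.3-fold lower number from compound 2 to compound 4 (0.87 log units; beyond the scatter), the largest step among these compounds.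

No evidence here accounts for the gap between phenyl and (dimethylamino)methyl. Still open, from the compounds shown here alone, is how this read-out would respond to a pyridine ring at this place, or to a methoxy group or a chlorine on the phenyl ring.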